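Swapping a methoxypyridine for a hydroxy-methoxybenzyl group

This account rests on a few compounds, and the source may have more. Where it says the series, first, only, none or still open, it means among the compounds named here.

Of the compounds shown here, three sharing a substituted tetrahydropyran core have been measured in an assay on Cerebral cortex for inhibition of Norepinephrine transporter (Rattus norvegicus); a higher number here means a weaker inhibitor, a lower number a stronger inhibitor. Compound 1 `O[C@@H]1C[C@@H](C(c2ccc(F)cc2)c2ccc(F)cc2)OC[C@H]1NCc1ccc2c(c1)CCO2` gives 25.8 nM. Compound 2 `COc1ccc(CN[C@@H]2CO[C@H](C(c3ccccc3)c3ccccc3)C[C@H]2O)cn1` gives 38.1 nM. Compound 3 `c1ccc(C(c2ccccc2)[C@@H]2CC[C@H](NCc3ccc4occc4c3)CO2)cc1` gives 25.2 nM. Compound 2 stands with the other two: its value is within the usual scatter of compound 1 and likewise within the scatter of compound 3, so the three numbers cannot be told apart.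

Compound 4 `COc1cc(O)cc(CN[C@@H]2CO[C@H](C(c3ccccc3)c3ccccc3)C[C@H]2O)c1` has not been measured in this assay. It differs from compound 2 in one place: 3-hydroxy-5-methoxyphenyl in place of 6-methoxypyridin-3-yl on a saturated chain carbon bound to an amine nitrogen. Within the data shown here, no pair of measured compounds shows this or any other single change, so there is no measured step to lean on.

Since the three measured compounds, with different benzylic groups on the amine, all land within the scatter of one another, the expectation for compound 4 is a step of roughly no size beyond the scatter, a 1.2-fold higher number from compound 2 to compound 4 (0.07 log units; within the scatter), with a slight lean toward a weaker inhibitor. Compound 4 is therefore estimated at 45 nM in this assay, with a range from 15 nM to 150 nM.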

Compound 4, inhibition constant: 44.2 nM
Compound 4: middle estimate off by 1.0-fold (0.01 log units), on the high side, within the range that was stated.
By their numbers in this assay, from the lowest: compounds 3, 1, 2 and 4 (each within the scatter of the next).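

Among these compounds, the first comparison in this set that differs in only one place is a step in this assay of (a 1.2-fold higher number from compound 2 to compound 4 (0.06 log units; within the scatter)), so exchanging the 6-methoxypyridin-3-yl group for 3-hydroxy-5-methoxyphenyl on a saturated chain carbon bound to an amine nitrogen cannot be told apart from no change at all. This single exchange removes the ring nitrogen, leaving a ring of carbon only, and brings in a hydrogen-bond donor, yet neither alters the reading beyond the scatter, whether the two act separately or cancel out. Nothing measured explains why the number holds steady across this exchange.

The compounds shown do not separate the ring nitrogen from the hydroxyl, and a plain 3-methoxyphenyl group at the same place would be needed to take those two apart. They also leave open whether this place stays as undemanding with a carboxylic acid on the aromatic ring or with a longer chain joining that ring to the amine nitrogen, either of which could move the number beyond the scatter.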